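Lengthening the chain: from nitrile to dimethylcarbamoyl end

A few compounds are considered here, and "the series" means these few. Any claim that something is new, unique, unknown or untested is made for them only; others in the source may bear on it.

Measured compounds:
compound 1, `C=CCc1cc(C(C)=O)c(O)cc1OCCCC#N`: 6%
compound 2, `CCc1cc(C(C)=O)c(O)cc1OCCCCCn1cncn1`: 30%

Of the compounds shown here, two sharing the same core have been measured in an assay on isolated protein for binding affinity to leukotriene B4 receptor 1 (Homo sapiens), tested at 1 uM; a higher number here means more inhibition at the concentration tested (going by the name of the read-out), a lower number less inhibition. Compound 1 gives 6% in this assay, the lower of the two numbers. Compound 2 gives 30%, a value that lies beyond the scatter above that of compound 1; since the two differ in more than one place, the gap cannot be traced to any single change.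

Compound 3, `C=CCc1cc(C(C)=O)c(O)cc1OCCCCCC(=O)N(C)C`, has not yet been measured. It differs from compound 1 in one place: 2-(dimethylcarbamoyl)ethyl in place of cyano on a saturated chain carbon, three bonds along the chain from an oxygen on an aromatic ring. The chain on the aromatic oxygen thereby grows longer, and the nitrile end is replaced by a dimethylcarbamoyl end.

Among the compounds with values here, no single-change step between measured compounds exists to calibrate this, so the expectation rests on the low reading of compound 1 and the higher reading of compound 2. The step expected a number 9 percentage points higher from compound 1 to compound 3 (within the scatter) is small and upward, near the edge of the scatter. For compound 3 in this assay the estimated inhibition is 15%, with a range from 0% to 38%.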

Compound 3, a percentage reported as inhibition, at one concentration (the size of the read-out at that concentration, not a potency): 54%
Compound 3: middle estimate off by 39 percentage points, on the low side, and the stated range ends below it.
By their numbers in this assay, from the lowest: compound 1; then compound 2; then compound 3.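

In this assay, putting 2-(dimethylcarbamoyl)ethyl in place of cyano on a saturated chain carbon, three bonds along the chain from an oxygen on an aromatic ring, makes the reading come out a number 48 percentage points higher from compound 1 to compound 3 (beyond the scatter). Within the data shown here, this is the first step that can be read as a single change, and it shows that, with the rest of the core of compound 1 unchanged, this position on the chain is not indifferent to what is placed there: the exchange of the short nitrile end for the larger dimethylcarbamoyl-bearing group moves the read-out by a large amount. No accompanying measurement speaks to what lies behind this rise.

The one step lengthens the chain and replaces its end together, so the compounds shown leave open how much of the rise belongs to the added chain length and how much to the dimethylcarbamoyl end. A longer chain still ending in a nitrile, or a chain of the same length as in compound 3 ending in a carboxylic acid or an amine, would begin to separate the two.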